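Swapping a six-membered ring for a five-membered one

This account rests on a few compounds, and the source may have more. Where it says the series, first, only, none or still open, it means among the compounds named here.

Of the compounds shown here, three sharing one core have been measured in an assay on HEK293 cells for displacement of a labelled ligand from Sigma non-opioid intracellular receptor 1 (Homo sapiens), read by scintillation counting, with a stated time of 120 min; a higher number here means a weaker inhibitor, a lower number a stronger inhibitor. Compound 1 `CNC1CCN(c2ncnc3c2cnn3CCN2CCCCC2)C1` gives 25800 nM, compound 2 `Cc1ccc(C)c(-c2ncnc3c2cnn3CCN2CCCCC2)c1` gives 63 nM, and compound 3 `c1ccc(-c2ncnc3c2cnn3CCN2CCCCC2)nc1` gives 634 nM. Compound 3 thus stands second highest of the three: a 10-fold higher number from compound 2 to compound 3 (1.00 log units; beyond the scatter), while a 41-fold lower number from compound 1 to compound 3 (1.61 log units; beyond the scatter) and a 410-fold lower number from compound 1 to compound 2 (2.61 log units; beyond the scatter). Compound 4 `c1nc(-c2cnsc2)c2cnn(CCN3CCCCC3)c2n1` differs from compound 3 by 1,2-thiazol-4-yl in place of pyridin-2-yl on an aromatic carbon. Among the measured compounds shown here, no measured step exchanges one small aromatic ring for another; the nearest guide is the aryl-to-pyridyl step, which was modest. The expected change is therefore small, likely a 1.3-fold higher number from compound 3 to compound 4 (0.10 log units; within the scatter) in this assay. Compound 4 is estimated at 800 nM, within the range 200 nM to 4000 nM.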

Compound 4, inhibition constant: 475 nM
Compound 4: middle estimate off by 1.7-fold (0.23 log units), on the high side; measured number inside the range.
By their numbers in this assay, from the lowest: compound 2; then compounds 4 and 3 (each within the scatter of the next); then compound 1.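

In this assay, exchanging the six-membered pyridin-2-yl ring for the five-membered 1,2-thiazol-4-yl ring on this aromatic carbon leaves the result within the scatter (a 1.3-fold lower number from compound 3 to compound 4 (0.13 log units; within the scatter)). Here, this change in ring size and hetero atoms does not separate the two compounds, while the larger gaps remain (a 7.5-fold higher number from compound 2 to compound 4 (0.88 log units; beyond the scatter); a 54-fold lower number from compound 1 to compound 4 (1.73 log units; beyond the scatter)). No measurement here explains these results.

Still open, on these data alone, is how an unsubstituted phenyl ring, or a phenyl ring bearing a single methyl group, would read on this carbon.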